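A few compounds are considered here, and "the series" means these few. Any claim that something is new, unique, unknown or untested is made for them only; others in the source may bear on it.

Compound 2 `COc1cc(-c2nc3ccccc3c(=O)[nH]2)ccc1OCc1ccc(F)cc1` sits at the top of the two numbers in hand in an ADME assay on cells for inhibition of cytochrome P450 1A1 (Homo sapiens), read by fluorescence, tested at 10 uM (on this read-out higher numbers stand for more inhibition at the one concentration tested (going by the name of the read-out) and lower numbers for less inhibition), where compound 2 gives 24.9%. Within the data shown here, compound 1 `COc1cc(-c2nc3ccccc3c(=O)[nH]2)ccc1OCc1ccc(Cl)cc1Cl` gives 24.1%, and the only measured step, a number 0.8 percentage points higher from compound 1 to compound 2 (within the scatter), lies within the scatter. Compound 3 `COc1cc(-c2nc3ccccc3c(=O)[nH]2)ccc1OS(C)(=O)=O` differs from compound 2 by methylsulfonyl in place of 4-fluorobenzyl on an oxygen on an aromatic ring. Among the measured compounds shown here, no measured step touches this position in a comparable way, so the measured step from compound 1 to compound 2 offers little guidance beyond showing that swapping the group on this oxygen changed little. Compound 3 is therefore expected near compound 2, with a wide range: 20% (5% to 40%), an estimated step of a number 4.9 percentage points lower from compound 2 to compound 3 (within the scatter).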

Compound 3, a percentage reported as inhibition, at one concentration (the size of the read-out at that concentration, not a potency): 12%
Compound 3: the middle estimate sits 8 percentage points above what was measured, within the range that was stated.
By their numbers in this assay, from the lowest: compound 3; then compounds 1 and 2 (each within the scatter of the next).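

In this assay, the group on the oxygen on an aromatic ring can shift the read-out: the change to methylsulfonyl gives a number 12.9 percentage points lower from compound 2 to compound 3 (beyond the scatter) and a number 12.1 percentage points lower from compound 1 to compound 3 (beyond the scatter) as its two steps, both beyond the scatter. Among these compounds, the earlier swap between the two benzyl groups stayed within the scatter, so this is the first sign that the position responds. Nothing at hand bears on the reason for this drop. Still open, on these data alone, is whether the aromatic ring or the sulfonyl matters here; a plain methyl, a longer alkyl chain or a free hydroxyl on this oxygen would help separate the two.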